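Swapping the aryl amide of compound 1 for a chloro-methyl ring

This account rests on a few compounds, and the source may have more. Where it says the series, first, only, none or still open, it means among the compounds named here.

Compound 1 `C=Cc1cccc(C(=O)NCN2CCC(c3cccc[n+]3[O-])CC2)c1` has the lowest number of the three measured compounds: in a functional assay on HEK293 cells for agonist activity at D(4) dopamine receptor (Homo sapiens), read by FLIPR (a higher number here means that more compound is needed for the effect, a lower number that less compound is needed), compound 1 gives 68 nM, while compound 3 `CCOc1cccc(C(=O)NCN2CCC(c3cccc[n+]3[O-])CC2)c1` gives 324 nM and compound 2 `O=C(CN1CCC(c2cccc[n+]2[O-])CC1)Nc1cccc(-c2ccccc2)c1` gives 360 nM. Compound 4 `Cc1cc(C(=O)NCN2CCC(c3cccc[n+]3[O-])CC2)ccc1Cl` differs from compound 1 by 4-chloro-3-methylphenyl in place of 3-vinylphenyl on a carbonyl carbon. Going by the values given here, only one measured step touches the same aromatic ring: a 4.8-fold higher number from compound 1 to compound 3 (0.68 log units; beyond the scatter). Compound 2 changes the linker instead and offers no direct guidance. Among the compounds with values here, since the one relevant change away from vinyl cost potency, a similar loss of modest size is expected for the step of a 2.4-fold higher number from compound 1 to compound 4 (0.37 log units; beyond the scatter). Compound 4 is therefore estimated at 160 nM, with a likely range from 50 nM to 500 nM.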

Compound 4, half-maximal effective concentration: 2460 nM
Compound 4: middle estimate off by 15-fold (1.19 log units), on the low side; the whole stated range lies below it.
By their numbers in this assay, from the lowest: compound 1; then compounds 3 and 2 (each within the scatter of the next); then compound 4.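

At this carbonyl carbon, 4-chloro-3-methylphenyl in place of 3-vinylphenyl gives a 36-fold higher number from compound 1 to compound 4 (1.56 log units; beyond the scatter) in this assay, a large step where the ethoxy change on the same ring gave only a 4.8-fold higher number from compound 1 to compound 3 (0.68 log units; beyond the scatter). Both groups have the same heavy-atom count and neither has hydrogen-bond donors or acceptors, so these counts do not account for the difference in the numbers. No measurement at hand explains the loss. As far as these compounds go, it remains open whether the chlorine, the methyl or their combination carries the step, which 4-chlorophenyl and 3-methylphenyl at this carbon would help separate.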